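The compounds below may be only part of what the source reports. "The series", "measured", "known", "first", "only" and "open" are said of these compounds alone.

Compound 1 `O=C(CCc1cccc2c1B(O)OC2)Nc1cccc(-c2ccc(F)cc2)c1`: 250 nM
Compound 2 `O=C(CCc1cccc2c1B(O)OC2)Nc1cccc(-c2cccc(OC(F)(F)F)c2)c1`: 460 nM

These two compounds share a core and differ in the groups on the far end of the molecule. In a functional assay on MDA-MB-231 cells (Homo sapiens) for antiproliferative activity, read by MTT assay, with a stated time of 72 h (a higher number here means a weaker inhibitor, a lower number a stronger inhibitor), compound 2 gives 460 nM, and this cannot be told apart from compound 1 at 250 nM, since the two numbers lie within the usual scatter of repeated measurements. Going by the values given here, compound 2 therefore stands level with its only measured neighbour.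

The next compound, compound 3 `O=C(CCc1cccc2c1B(O)OC2)Nc1cccc(-c2cccc(C(F)(F)F)c2)c1`, keeps everything in compound 2 except one group. It has trifluoromethyl in place of trifluoromethoxy on an aromatic carbon, meta to a large group (trifluoromethyl in place of trifluoromethoxy on an aromatic carbon).

Among the compounds with values here, no two measured compounds differ in one place only, so no measured step shows what this swap does, and any forecast is a judgement. The swap is small, and the two different end groups of compound 1 at 250 nM and compound 2 at 460 nM gave values within the scatter, so no change beyond the scatter is expected. The expected step is a 1.2-fold lower number from compound 2 to compound 3 (0.08 log units; within the scatter), an estimate and no more. For compound 3 the estimated value is 380 nM, with an expected range of 170 nM to 850 nM.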

Compound 3, half-maximal inhibitory concentration: 410 nM
Beside the measured number, compound 3's estimate is 1.1-fold (0.03 log units) below it; measured number inside the range.
By their numbers in this assay, from the lowest: compounds 1, 3 and 2 (each within the scatter of the next).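

In this assay, going by these compounds alone, the swap of trifluoromethoxy for trifluoromethyl, on an aromatic carbon meta to a large group, gives a 1.1-fold lower number from compound 2 to compound 3 (0.05 log units; within the scatter) and is the first change in this set made at a single place. Losing the oxygen of trifluoromethoxy therefore moves the number by no more than repeat measurements would, at least with this pair of groups. The larger exchange of 3-(trifluoromethyl)phenyl in place of 4-fluorophenyl gives a 1.6-fold higher number from compound 1 to compound 3 (0.21 log units; within the scatter) and also stays inside that scatter, so compound 1, compound 2 and compound 3 stand level and these three end groups cannot be ranked in this cell assay.

Going by these compounds, all three end groups carry fluorine on an aromatic ring, so it remains open whether an amine or a carboxylic acid on that ring, or a ring with no fluorine at all, would shift the number beyond the scatter. Nothing available here explains why these changes leave the cell result level, and how the compounds act on the cells also stays unaddressed.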